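Cytotoxicity of Chalcone Analogues: From Hydroxy-Methoxy to Chloro

A few compounds are considered here, and "the series" means these few. Any claim that something is new, unique, unknown or untested is made for them only; others in the source may bear on it.

Measured so far:
compound 1, `C=CCOc1cc(OC)c(C(=O)/C=C/c2ccc(F)cc2)c(OCC=C)c1`, 13600 nM in an ADME assay on Vero cells (Chlorocebus sabaeus) for cytotoxicity, read by MTT assay; a lower number here means a stronger inhibitor, a higher number a weaker inhibitor
compound 2, `C=CCOc1cc(OC)c(C(=O)/C=C/c2cccc(OC)c2)c(OCC=C)c1`, 142000 nM in this assay
compound 3, `C=CCOc1cc(OC)c(C(=O)/C=C/c2ccc(O)c(OC)c2)c(OCC=C)c1`, "not determined" (no result reported) in this assay

Compound 3 has no number in this assay, so it cannot be placed against compound 1 or compound 2 at all. Going by the values given here, its only difference from compound 4 is 4-chlorophenyl in place of 4-hydroxy-3-methoxyphenyl on a double-bonded chain carbon bound to a double-bonded chain carbon. Compound 4 is `C=CCOc1cc(OC)c(C(=O)/C=C/c2ccc(Cl)cc2)c(OCC=C)c1` and has not yet been measured in this assay.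

Among the compounds with values here, the one measured step that speaks to this series is the exchange of the aryl group on the same chain carbon: a 10-fold higher number from compound 1 to compound 2 (1.02 log units; beyond the scatter). That step went from a 4-fluorophenyl group, a halogen at the same position as the chlorine now entering, to a 3-methoxyphenyl group. The change into compound 4 puts a halogen at that position again, and compound 1 is therefore the nearest measured reference. Within the data shown here, with no value for compound 3, no step from compound 3 to compound 4 can be sized; the account instead expects compound 4 to sit in the region of compound 1. In this assay compound 4 is accordingly estimated at 15000 nM, with a plausible span from 5000 nM to 50000 nM.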

Compound 4, half-maximal inhibitory concentration: 10400 nM
The estimate for compound 4 lay 1.4-fold (0.16 log units) above the measured number, within the range that was stated.
By their numbers in this assay, from the lowest: compounds 4 and 1 (each within the scatter of the next); then compound 2.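

In this assay the step of a 1.3-fold lower number from compound 1 to compound 4 (0.12 log units; within the scatter) lies within the scatter, so compound 1 and compound 4 stand level and the 4-fluorophenyl and 4-chlorophenyl groups cannot be told apart at this place on a double-bonded chain carbon. Until now, only the 4-fluorophenyl group could be set against the 3-methoxyphenyl group, but the step of a 14-fold lower number from compound 2 to compound 4 (1.14 log units; beyond the scatter) lies beyond the scatter and shows that the wide gap to compound 2 does not rest on fluoro alone: it appears with both halogen-bearing groups in these three compounds. Nothing available explains either result.

The compounds shown leave open whether the methoxy group itself or its place on the ring sets compound 2 apart, a question that 4-methoxyphenyl would address, and whether a bromo group or an amine at the same ring position would stay level with compound 1 and compound 4. Going by these compounds, the step that removes the 4-hydroxy-3-methoxyphenyl group of compound 3 cannot be read, so the effect of exchanging that group for 4-chlorophenyl remains unknown.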